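Compound 3 to compound 4: losing the sulfonylamino group

The compounds below may be only part of what the source reports. "The series", "measured", "known", "first", "only" and "open" are said of these compounds alone.

Measured in a functional assay on KB cells (Homo sapiens) for antiproliferative activity, read by sulforhodamine B assay, with a stated time of 48 h; a higher number here means a weaker inhibitor of growth, a lower number a stronger inhibitor of growth:
- compound 1 `Nc1ccccc1NC(=O)c1ccc(CCc2ccccc2NS(=O)(=O)c2ccccc2)cc1`: 456 nM
- compound 2 `Nc1ccccc1NC(=O)c1ccc(CCc2ccccc2NS(=O)(=O)c2ccc(F)cc2)cc1`: 884 nM
- compound 3 `N#Cc1ccc(S(=O)(=O)Nc2ccccc2CCc2ccc(C(=O)Nc3ccccc3N)cc2)cc1`: 790 nM

Compound 3 stands within the scatter of both others: a 1.1-fold lower number from compound 2 to compound 3 (0.05 log units; within the scatter) and a 1.7-fold higher number from compound 1 to compound 3 (0.24 log units; within the scatter). The remaining step, a 1.9-fold higher number from compound 1 to compound 2 (0.29 log units; within the scatter), is also within the scatter.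

Compound 4 `Nc1ccccc1NC(=O)c1ccc(CCc2ccccc2)cc1` has hydrogen in place of ((4-cyanophenyl)sulfonyl)amino on an aromatic carbon. The measured steps only exchange hydrogen, fluoro and cyano within that group, so they bear weakly on its complete loss. A step beyond the scatter is expected, tentatively towards a higher number, though no measurement fixes the direction. The expected step is a 1.9-fold higher number from compound 3 to compound 4 (0.28 log units; within the scatter). Compound 4 is estimated at 1500 nM, with an expected range of 450 nM to 5000 nM.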

Compound 4, concentration for 50% growth inhibition: > 10000 nM
Compound 4: no number, only a limit (the forecaster's own chance of this, stated with the estimate: 5%); at least 6.6-fold (0.82 log units) between middle value and limit.
By their numbers in this assay, from the lowest: compounds 1, 3 and 2 (each within the scatter of the next). At a limit, above all of these: compound 4.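

In this assay, compound 4 gives > 10000 nM, which is a limit of the assay and not a number. Exchanging hydrogen, fluoro and cyano within the group stayed within the scatter, whereas replacing the whole group with hydrogen on this aromatic carbon gives an at least 12-fold higher number from compound 3 to compound 4 (1.10 log units; beyond the scatter), an at least 11-fold higher number from compound 2 to compound 4 (1.05 log units; beyond the scatter) and an at least 21-fold higher number from compound 1 to compound 4 (1.34 log units; beyond the scatter). All three steps therefore rest on a limit, so their true size is unknown: the limit of > 10000 nM in this assay, at which 1 of the 4 values shown sits.

Open, going by these compounds, is which part of the group the numbers depend on. An amine or a methyl sulfonamide on this carbon would separate the nitrogen, the sulfonyl and the aromatic ring.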